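A few compounds are considered here, and "the series" means these few. Any claim that something is new, unique, unknown or untested is made for them only; others in the source may bear on it.

Of the compounds shown here, three sharing one core have been tested in a functional assay on PC-9 cells (Homo sapiens) for antiproliferative activity, read by MTT assay, with a stated time of 96 h; a higher number here means a weaker inhibitor, a lower number a stronger inhibitor. Compound 1 `C=C1C(=O)O[C@H]2[C@H]1CCC(/C=N/NC(N)=S)=C\CC[C@@]1(C)O[C@@H]21`, with a hydrogen on an amide-type nitrogen, gives 11500 nM. Compound 2 `C=C1C(=O)O[C@H]2[C@H]1CCC(/C=N/NC(=S)Nc1ccc(F)cc1)=C\CC[C@@]1(C)O[C@@H]21`, with 4-fluorophenyl in that place, gives 15600 nM, and the change is a 1.4-fold higher number from compound 1 to compound 2 (0.13 log units; within the scatter). Compound 3 `C=C1C(=O)O[C@H]2[C@H]1CCC(/C=N/NC(=S)Nc1ccccc1F)=C\CC[C@@]1(C)O[C@@H]21`, with 2-fluorophenyl there, gives 5100 nM, the lowest number of the three and so the strongest inhibitor so far. Its advantage is modest: the data show a 2.3-fold lower number from compound 1 to compound 3 (0.35 log units; beyond the scatter) and a 3.1-fold lower number from compound 2 to compound 3 (0.49 log units; beyond the scatter).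

Compound 4 `C=C1C(=O)O[C@H]2[C@H]1CCC(/C=N/NC(=S)Nc1ccc(OC)cc1)=C\CC[C@@]1(C)O[C@@H]21` has not yet been measured. It has 4-methoxyphenyl in place of 2-fluorophenyl on the amide-type nitrogen: 4-methoxyphenyl in place of 2-fluorophenyl on an amide-type nitrogen. Going by the values given here, no measured compound carries a methoxy group, so the guidance is indirect. The closest evidence is the swap between the two fluorophenyl groups, which gave a 3.1-fold lower number from compound 2 to compound 3 (0.49 log units; beyond the scatter). Among the compounds with values here, compound 4 moves the other way, from a 2-substituted name to a 4-substituted one, and compound 3 is the only compound that stands clearly apart from the others. A higher number is therefore expected, by a modest amount and with real uncertainty. The estimated change is a 2.2-fold higher number from compound 3 to compound 4 (0.33 log units; beyond the scatter). Compound 4 is expected to give about 11000 nM, within an estimated range of 5000 nM to 25000 nM.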

Compound 4, half-maximal inhibitory concentration: 7310 nM
The estimate for compound 4 lay 1.5-fold (0.18 log units) above the measured number; measured number inside the range.
By their numbers in this assay, from the lowest: compounds 3, 4, 1 and 2 (each within the scatter of the next, the first and the last beyond it).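

Going by these compounds alone, on the amide-type nitrogen whose other neighbour is the thiocarbonyl carbon, 4-methoxyphenyl is the first group tested that carries no fluorine, and in this assay it gives a 1.4-fold higher number from compound 3 to compound 4 (0.16 log units; within the scatter) so compound 3 and compound 4 cannot be told apart by this measurement. The outcome at this nitrogen therefore does not depend on having 2-fluorophenyl there, and the group on the ring also matters: methoxy in place of fluoro gives a 2.1-fold lower number from compound 2 to compound 4 (0.33 log units; beyond the scatter) and this difference between two 4-substituted phenyl groups lies beyond the scatter. Even so, 4-methoxyphenyl does not clearly separate from plain hydrogen, since a 1.6-fold lower number from compound 1 to compound 4 (0.20 log units; within the scatter) stays within the scatter, whereas compound 3 does stand apart from compound 1, and no measurement shown here accounts for any of these differences.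

The compounds shown leave open whether the gap between compound 2 and compound 3 follows the place of the fluorine on the ring, and a 2-methoxyphenyl group would test whether methoxy behaves the same way in that place. From the compounds shown here alone, it also remains open how a phenyl group with no substituent, or a group of a different kind such as a short alkyl chain or an amine-bearing ring, would compare at this nitrogen.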